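Swapping the hydroxyphenyl of compound 3 for thiophene

This account rests on a few compounds, and the source may have more. Where it says the series, first, only, none or still open, it means among the compounds named here.

Of the compounds shown here, three sharing one core have been measured in an assay on isolated protein for inhibition of Amine oxidase [flavin-containing] A (Homo sapiens), read by spectrophotometry; a lower number here means a stronger inhibitor, a higher number a weaker inhibitor. Compound 1, `C(=N/Nc1nc2ccccc2nc1Cc1ccccc1)\c1ccccc1`, gives 81 nM in this assay. Among the compounds with values here, compound 2, `COc1ccc(/C=N/Nc2nc3ccccc3nc2Cc2ccccc2)cc1`, gives 63 nM in this assay, and the only measured single step, a 1.3-fold lower number from compound 1 to compound 2 (0.11 log units; within the scatter), stays within the scatter. Within the data shown here, compound 3, `C/C(=N\Nc1nc2ccccc2nc1Cc1ccccc1)c1ccc(O)cc1`, gives 2.8 nM in this assay and stands lowest of the three numbers; it differs from compound 2 by a gap that is beyond the scatter and from compound 1 by a still larger gap, yet it differs from each of them in more than one place, so no single step is available for it.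

Compound 4, `C/C(=N\Nc1nc2ccccc2nc1Cc1ccccc1)c1cccs1`, carries the change (thiophen-2-yl in place of 4-hydroxyphenyl on a carbon with a double bond to nitrogen). Among the measured compounds shown here, none of the measured steps bears on this change: the one step recorded concerns a methoxy added on an aromatic carbon, not the exchange of a whole aryl group, and the hydroxy group that leaves here appears in no other measured compound. Compound 3 being the lowest number, a move away from its aryl group is expected to give a higher number in this assay, with the step of an 8.9-fold higher number from compound 3 to compound 4 (0.95 log units; beyond the scatter) set broadly to cover the uncertainty. Compound 4 is therefore estimated at 25 nM, within a range from 6 nM to 120 nM.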

Compound 4, half-maximal inhibitory concentration: 64 nM
Beside the measured number, compound 4's estimate is 2.6-fold (0.41 log units) below it; the range from low to high includes it.
By their numbers in this assay, from the lowest: compound 3; then compounds 2, 4 and 1 (each within the scatter of the next).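

Within the data shown here, with the group on a carbon with a double bond to nitrogen changed from 4-hydroxyphenyl to thiophen-2-yl, this assay shows a 23-fold higher number from compound 3 to compound 4 (1.36 log units; beyond the scatter), the first single step at this position and a large one, so the low number of compound 3 does not survive this exchange. The other new step, a 1.3-fold lower number from compound 1 to compound 4 (0.10 log units; within the scatter), lies within the scatter, which shows that the saturated chain carbon shared by compound 3 and compound 4 does not by itself bring a low number when thiophen-2-yl is present. No measurement on hand explains why the exchange has this size.

The compounds shown leave open whether the hydroxy group itself carries the gap or the six-membered aromatic ring does, since a plain phenyl, a 4-methoxyphenyl or a 4-aminophenyl on this same carbon, with its saturated chain carbon kept, does not appear among them. They also leave open whether a hydroxy group placed on the thiophene ring, or a carboxylic acid in its stead on the phenyl ring, would bring the number back towards that of compound 3.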